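Cytotoxicity series: propoxy to chloro on the aryl ring

The source may hold more compounds than are shown below. What is called first, only, known or untested is meant among the compounds shown, and "the series" means these compounds.

Measured so far:
compound 1 `CCOC(=O)c1c(-c2ccccc2)[nH]c2cc(OC)ccc2c1=O` – > 21500 nM
compound 2 `CCOC(=O)c1c(-c2cccc(OCC)c2)[nH]c2cc(OC)ccc2c1=O` – > 21500 nM
compound 3 `CCCOc1cccc(-c2[nH]c3cc(OC)ccc3c(=O)c2C(=O)OCC)c1` – > 21500 nM

In an ADME assay on BJ cells (Homo sapiens) for cytotoxicity, read by luminescence, with a stated time of 72 h (a higher number here means that more compound is needed for the effect, a lower number that less compound is needed), compound 1 gives > 21500 nM, which is a limit of the assay and not a number. Compound 2 likewise stops at > 21500 nM, a limit. Compound 3 also reaches only the limit > 21500 nM. Compound 3 therefore stands where the other two stand, at the limit of > 21500 nM in this assay, at which 3 of the 3 values shown sit, and nothing in the numbers separates it from compound 1 or compound 2.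

The steps measured among these three are a step that the two limits leave unreadable from compound 1 to compound 2, a step that the two limits leave unreadable from compound 1 to compound 3 and a step that the two limits leave unreadable from compound 2 to compound 3; all are unreadable, since both ends sit at the limit.

Compound 4 `CCOC(=O)c1c(-c2cccc(Cl)c2)[nH]c2cc(OC)ccc2c1=O` is the next member. It differs from compound 3 as follows: chloro in place of propoxy on an aromatic carbon.

Within the data shown here, no measured step bears directly on a chloro group, and the three steps available give no size at all. Among the measured compounds shown here, the only guidance is that every compound so far sits at the limit. For compound 4 a step that the limit leaves unreadable from compound 3 to compound 4 is therefore expected, which is to say none beyond the scatter. Compound 4 is expected to give about 30000 nM, within a range from 12000 nM to 90000 nM, most likely again as a limit.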

Compound 4, half-maximal effective concentration: > 21500 nM
Compound 4: a limit, no number (the forecaster's own chance of this, stated with the estimate: 80%); the middle value lies beyond the limit too.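

In this assay compound 4 also ends at a limit and not at a number, so the steps to it from compound 1, compound 2 and compound 3 cannot be read, and all four stand together: the limit of > 21500 nM in this assay, at which 4 of the 4 values shown sit.

What the compounds shown leave open is whether hydrogen, ethoxy, propoxy and chloro on the aromatic carbon differ at all in cytotoxicity; none of the four gives a number.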